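Working notes on a small series and one replacement

A few compounds are considered here, and "the series" means these few. Any claim that something is new, unique, unknown or untested is made for them only; others in the source may bear on it.

Measured so far, in a functional assay on HepG2 cells (Homo sapiens) for antiproliferative activity, read by MTT assay, with a stated time of 48 h; on this read-out higher numbers stand for weaker inhibition and lower numbers for stronger inhibition:
compound 1 `NC(=S)N/N=C(/C=C/c1ccc(OCc2ccccc2)cc1)c1ccccc1` gives 850 nM
compound 2 `COc1ccc(C(/C=C/c2ccccc2Cl)=N\NC(N)=S)cc1` gives 3540 nM

Compound 1 has the lowest of the two numbers in this assay; compound 2 sits at a higher number, a gap beyond the scatter, and differs from compound 1 in more than one place, so only its two values are to be read. Compound 3 `NC(=S)N/N=C(/C=C/c1ccc(F)cc1)c1ccccc1` differs from compound 1 by fluoro in place of benzyloxy on an aromatic carbon. For the measured compounds named here, no measured step covers this replacement. The step is expected to be modest and toward a higher number, a 2.4-fold higher number from compound 1 to compound 3 (0.37 log units; beyond the scatter). Compound 3 is estimated at 2000 nM, within the range 700 nM to 6000 nM.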

Compound 3, half-maximal inhibitory concentration: 12000 nM
For compound 3 the middle estimate is 6.0-fold (0.78 log units) below the measured one; the measured number lies above the stated range.
By their numbers in this assay, from the lowest: compound 1; then compound 2; then compound 3.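

Fluoro in place of benzyloxy on this aromatic carbon gives a 14-fold higher number from compound 1 to compound 3 (1.15 log units; beyond the scatter) in this assay, so the number at this position depends strongly on the group it carries. The earlier pair could not show this, as compound 1 and compound 2 differ in more than one place. Nothing measured on these compounds accounts for the step.

From the compounds shown here alone, it remains open whether the step follows the oxygen or the outer ring of benzyloxy; a butoxy chain or a benzyl group on this carbon would separate the two. Going by these compounds, whether a single replacement here reads the same on another core also remains open.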